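The source may report more compounds than this note shows. Statements on the series, on what has been measured and on what is new or still open speak of the compounds shown alone.

Compounds measured so far:
- compound 1 `COc1ccc(SCc2ccc(/C=C/C(=O)Nc3ccccc3N)cc2)cc1OC` gives 65.5%
- compound 2 `Nc1ccccc1NC(=O)c1ccc(CSc2ccc(Br)cc2)cc1` gives 33.2%
- compound 3 `COc1ccc(SCc2ccc(C(=O)Nc3ccccc3N)cc2)cc1` gives 45.7%

In a functional assay on A549 cells (Homo sapiens) for inhibition, read by CCK-8 assay, with a stated time of 72 h, tested at 2 uM (a higher number here means more inhibition of growth at the concentration tested, a lower number less inhibition of growth), compound 1 stands highest of the three numbers, with compound 3 nearest and compound 2 furthest, both beyond the scatter. Among the compounds with values here, the one change measured in a single place runs between compound 2 and compound 3: methoxy in place of bromo on an aromatic carbon, giving a number 12.5 percentage points higher from compound 2 to compound 3 (beyond the scatter), a modest gain.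

Compound 4 `Nc1ccccc1NC(=O)/C=C/c1ccc(CSc2cccc(F)c2)cc1` is not yet measured. It differs from compound 1 in one place: 3-fluorophenyl in place of 3,4-dimethoxyphenyl on a sulfur. Here both methoxy groups leave and a fluorine, another halogen, enters. Within the data shown here, the only step that bears on this is the one from compound 2 to compound 3, where a methoxy gave a modestly higher number than a halogen; the reverse exchange therefore suggests a modest fall. Compound 4 is expected to give 50%, within 35% to 65%, a step of a number 15.5 percentage points lower from compound 1 to compound 4 (beyond the scatter) that is estimated to lie beyond the scatter.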

Compound 4, percent growth inhibition at one concentration: 50.7%
Beside the measured number, compound 4's estimate is 0.7 percentage points below it; the measured number falls inside the stated range.
By their numbers in this assay, from the lowest: compound 2; then compounds 3 and 4 (each within the scatter of the next); then compound 1.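

In this assay, putting 3-fluorophenyl in place of 3,4-dimethoxyphenyl on a sulfur gives a number 14.8 percentage points lower from compound 1 to compound 4 (beyond the scatter). This shows that the group on the sulfur also matters on the core of compound 1, whereas the earlier single-place step came from the different core shared by compound 2 and compound 3. Both methoxy groups leave and a fluorine enters in this one change, so the step cannot be assigned to either part of it, and nothing measured here gives a reason for the fall.

From the compounds shown here alone, it remains open whether a single methoxy on the core of compound 1 would hold the higher number. Going by these compounds, it is also open how a ring on the sulfur carrying a nitrile or a carboxylic acid would behave.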